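This account rests on a few compounds, and the source may have more. Where it says the series, first, only, none or still open, it means among the compounds named here.

Working notes on the series.

Compound 1 `COc1cc(/C=N/Nc2nc(-c3ccc(F)c(F)c3)cs2)cc(Br)c1OC` and compound 2 `COc1cc(/C=N/Nc2nc(-c3ccc(F)c(F)c3)cs2)c(Br)c(Br)c1OC` are built on one shared core and differ at a single aromatic carbon. In a functional assay on U-87MG ATCC cells for inhibition, with U-87 MG (Homo sapiens) as the target, read by MTT assay, with a stated time of 48 h (a higher number here means a weaker inhibitor, a lower number a stronger inhibitor), compound 1 gives 26300 nM. In this assay compound 2 gives 19600 nM. The step between them, (hydrogen in place of bromo on an aromatic carbon), reads a 1.3-fold higher number from compound 2 to compound 1 (0.13 log units; within the scatter), so the two values are not distinguished by this assay.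

Compound 3 `Fc1ccc(/C=N/Nc2nc(-c3ccc(Br)cc3)cs2)cc1F` belongs to a different core; the difference between the core of compound 3 and the core of compound 2 is not broken down here. In this assay compound 3 gives only a limit, > 100000 nM, and no number; this is the limit of > 100000 nM in this assay, at which 1 of the 3 values shown sits.

Compound 4 `Fc1ccc(/C=N/Nc2nc(-c3ccccc3)cs2)cc1F` is the not yet measured partner of compound 3, made by hydrogen in place of bromo on an aromatic carbon. This is the same kind of change as that from compound 2 to compound 1, not the same one: in compound 2 the leaving bromo sits ortho to a bromo group, ortho to a large group, meta to a methoxy group and para to a methoxy group, whereas in compound 3 it sits para to a large group.

The step from compound 3 to compound 4 in this assay is expected to be a step that the limit leaves unreadable from compound 3 to compound 4, resting on the near-flat a 1.3-fold higher number from compound 2 to compound 1 (0.13 log units; within the scatter) and on compound 3 standing at a limit of > 100000 nM. Compound 4 is therefore estimated at 150000 nM, within a range from 50000 nM to 500000 nM, most likely reported again only as a limit.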

Compound 4, half-maximal inhibitory concentration: > 100000 nM
Compound 4 ended at the assay's limit; the forecaster's own chance of this, stated with the estimate: 70%; the middle value lies beyond the limit too.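

In this assay compound 3 and compound 4 both stand only at a limit, so no new step can be read between them: the limit of > 100000 nM in this assay, at which 2 of the 4 values shown sit.

The compounds shown leave open how large the change from 4-bromophenyl to phenyl is on this core, and whether it is as small as the step between compound 1 and compound 2, the same kind of change in another place.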